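A Nitro Group Carried From One Core to Another

The source may hold more compounds than are shown below. What is called first, only, known or untested is meant among the compounds shown, and "the series" means these compounds.

Compound 1 `CCCCCOCc1cc(=O)c2ccccc2[nH]1` and compound 2 `CCCCCOCc1cc(=O)c2cc([N+](=O)[O-])ccc2[nH]1` share one core, while compound 3 `CCCCCCCc1[nH]c2ccccc2c(=O)c1C(N)=O` has a different one; the difference between the two cores is not broken down here. In a physicochemical assay for solubility, read by HPLC, at pH 7.4 (a higher number here means a more soluble compound, a lower number a less soluble compound), compound 1 gives > 200000 nM, which is a limit of the assay rather than a number, namely (the limit of > 200000 nM in this assay, at which 1 of the 3 values shown sits). In this assay compound 2 gives 15000 nM. Between them stands the change (nitro in place of hydrogen on an aromatic carbon), which produced an at least 13-fold lower number from compound 1 to compound 2 (1.12 log units; beyond the scatter). In this assay compound 3 gives 5000 nM. Compound 4 `CCCCCCCc1[nH]c2ccc([N+](=O)[O-])cc2c(=O)c1C(N)=O` differs from compound 3 by the same change, (nitro in place of hydrogen on an aromatic carbon). Beside the measured step, a step of similar size, a 13-fold lower number from compound 3 to compound 4 (1.10 log units; beyond the scatter), is expected, because the earlier case showed an at least 13-fold lower number from compound 1 to compound 2 (1.12 log units; beyond the scatter). Compound 4 is therefore estimated at 400 nM, expected to lie between 100 nM and 2000 nM.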

Compound 4, solubility: 15000 nM
Compound 4: middle estimate off by 38-fold (1.57 log units), on the low side; measured number above the stated range.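

In this assay, nitro in place of hydrogen on an aromatic carbon gave a 3.0-fold higher number from compound 3 to compound 4 (0.48 log units; beyond the scatter), whereas on the other core it gave an at least 13-fold lower number from compound 1 to compound 2 (1.12 log units; beyond the scatter), so the same change moved the number in opposite directions. In these two cases the step therefore did not carry from one core to the other in size or direction, and the two pairs do not show which difference between the cores goes with this reversal. Compound 1 stands at a limit of the assay and not at a number: the limit of > 200000 nM in this assay, at which 1 of the 4 values shown sits.

The compounds shown leave open whether an amine or a carboxylic acid in the same place would also give opposite steps on the two cores. They also leave open whether the reversal would persist with a longer chain on either core.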